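Ring amine methylation: compound 2 to compound 3

This account rests on a few compounds, and the source may have more. Where it says the series, first, only, none or still open, it means among the compounds named here.

The series is followed in a functional assay on A2780 cells (Homo sapiens) for cytotoxicity, read by MTT assay, with a stated time of 48 h; a lower number here means a stronger inhibitor, a higher number a weaker inhibitor. Compound 1 `CCn1cc(-c2nc3ccccc3[nH]2)c(=O)c2cc(F)c(N3CCN(C)CC3)cc21` reaches only a limit of this assay, > 5010000 nM. For the measured compounds named here, compound 2 `CCn1cc(-c2nc3ccc(N)cc3[nH]2)c(=O)c2cc(F)c(N3CCNCC3)cc21` gives 51500 nM in this assay, and this is the only number so far. Going by the values given here, the one other value shown, (the limit of > 5010000 nM in this assay, at which 1 of the 2 values shown sits), is a limit and not a number. Compound 1 and compound 2 differ in more than one place, so their two values do not define a step. Compound 3 `CCn1cc(-c2nc3ccc(N)cc3[nH]2)c(=O)c2cc(F)c(N3CCN(C)CC3)cc21` differs from compound 2 in one place: methyl in place of hydrogen on an amine nitrogen in a ring. Among the compounds with values here, no step between two measured compounds is available, so this change has no measured precedent. For compound 3 the step of a 1.4-fold higher number from compound 2 to compound 3 (0.13 log units; within the scatter) is expected, a small move toward weaker inhibition that need not exceed the scatter. Compound 3 is estimated at 70000 nM, within 20000 nM to 300000 nM.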

Compound 3, half-maximal inhibitory concentration: > 50000 nM
Compound 3: a limit, no number; the forecaster's own chance of this, stated with the estimate: 20%; the middle value does not contradict the limit.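

Compound 3 gives only a limit, not a number, in this assay: > 50000 nM. The steps to compound 3 from compound 2 and from compound 1 therefore cannot be read. The compounds shown leave open the direction and size of the change when methyl replaces hydrogen on an amine nitrogen in a ring.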